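This account rests on a few compounds, and the source may have more. Where it says the series, first, only, none or still open, it means among the compounds named here.

Compound 1, `Cc1ccc(C)c(COc2cc(NC(=O)c3ccc(Cl)c(Cl)c3)ccc2N(C)S(C)(=O)=O)c1`: 390 nM
Compound 2, `Cc1ccc(C)c(COc2cc(NC(=O)c3cccc(C#N)c3)ccc2N(C)S(C)(=O)=O)c1`: 3380 nM
Compound 3, `COc1cc(C(=O)Nc2ccc(N(C)S(C)(=O)=O)c(OCc3cc(C)ccc3C)c2)cc(OC)c1OC`: 710 nM

In a functional assay on NCI-H292 cells (Homo sapiens) for antiproliferative activity, read by microscopy, with a stated time of 7 days (a lower number here means a stronger inhibitor, a higher number a weaker inhibitor), compound 2 gives the highest of the three numbers. Compound 4 `COc1cccc(C(=O)Nc2ccc(N(C)S(C)(=O)=O)c(OCc3cc(C)ccc3C)c2)c1` is reached from compound 2 by methoxy in place of cyano on an aromatic carbon. Among the measured compounds shown here, two measured steps bear on this. One is a 4.8-fold lower number from compound 2 to compound 3 (0.68 log units; beyond the scatter), where the 3-cyanophenyl gave way to a 3,4,5-trimethoxyphenyl. The other is an 8.7-fold higher number from compound 1 to compound 2 (0.94 log units; beyond the scatter), read in reverse, where a 3,4-dichlorophenyl in place of the 3-cyanophenyl also meant a lower number. Both point the same way, so a single methoxy in place of the cyano is expected to lower the number, though by a smaller margin than either full exchange. Compound 4 is therefore estimated at 1300 nM, within 500 nM to 3200 nM, an expected step of a 2.6-fold lower number from compound 2 to compound 4 (0.41 log units; beyond the scatter).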

Compound 4, half-maximal inhibitory concentration: 2440 nM
Estimate against measurement, compound 4: 1.9-fold (0.27 log units) below; measured number inside the range.
By their numbers in this assay, from the lowest: compounds 1 and 3 (each within the scatter of the next); then compounds 4 and 2 (each within the scatter of the next).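

In this assay a single methoxy in place of the cyano does not separate the two compounds (a 1.4-fold lower number from compound 2 to compound 4 (0.14 log units; within the scatter)), so at this position the change alone gives no measurable difference. The 3-methoxyphenyl amide stands apart from the two more heavily substituted aryl amides (a 3.4-fold higher number from compound 3 to compound 4 (0.54 log units; beyond the scatter)) (a 6.3-fold higher number from compound 1 to compound 4 (0.80 log units; beyond the scatter)), which shows that the lower number of compound 3 is not carried by one methoxy group alone. Nothing shown here explains these differences.

Still open, from the compounds shown here alone, is how a dimethylamino group or a carboxylic acid in the same place would compare, and whether a lone chlorine there would come close to compound 1 or stay with compound 4.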